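The source may report more compounds than this note shows. Statements on the series, on what has been measured and on what is new or still open speak of the compounds shown alone.

Measured in a functional assay on A2780 cells (Homo sapiens) for inhibition; on this read-out lower numbers stand for stronger inhibition and higher numbers for weaker inhibition:

Compound 1 `CC(C(=O)Nc1cc(C2CC2)[nH]n1)c1ccc(N2C(=O)CCC2C)cc1`: 6400 nM
Compound 2 `CC(C(=O)Nc1cc(C2CC2)[nH]n1)c1ccc(N2C(=O)CCC2c2ccccc2)cc1`: 15300 nM
Compound 3 `C[C@@H](C(=O)Nc1cc(C2CC2)[nH]n1)c1ccc(N2CCNC2=O)cc1`: 13200 nM

Of these three, compound 1 has the lowest number, at 6400 nM. The account now turns to compound 4 `CC(C(=O)Nc1cc(C2CC2)[nH]n1)c1ccc(N2CCCC2)cc1`, not yet measured in this assay. Its structural change from compound 1 is a group of 5 heavy atoms (4 carbon, 1 nitrogen; one five-membered non-aromatic ring with 1 hetero atom) in place of a group of 7 heavy atoms (5 carbon, 1 nitrogen, 1 oxygen; one five-membered non-aromatic ring with 1 hetero atom), on an aromatic carbon. In words, a group of 5 heavy atoms takes the place of a group of 7 heavy atoms on an aromatic carbon, para to a large group.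

Within the data shown here, only one measured step touches the group that changes. That step, a 2.4-fold higher number from compound 1 to compound 2 (0.38 log units; beyond the scatter), is modest and involves phenyl in place of methyl on a saturated ring carbon. It alters a substituent of the leaving group and does not replace the group as a whole, so it bears on compound 4 only loosely. Compound 3 carries yet another group on that aromatic carbon and gives 13200 nM. The data hold no measured case of the exact replacement, so the three values serve only as a rough frame. No step beyond the scatter is therefore expected, and the expected step is a 1.3-fold higher number from compound 1 to compound 4 (0.12 log units; within the scatter).

For compound 4 the estimated value is 8500 nM, with an expected range from 3000 nM to 22000 nM.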

Compound 4, half-maximal inhibitory concentration: 370 nM
Compound 4: middle estimate off by 23-fold (1.36 log units), on the high side, outside the stated range (below it).
By their numbers in this assay, from the lowest: compound 4; then compound 1; then compounds 3 and 2 (each within the scatter of the next).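

In this assay, putting pyrrolidin-1-yl on this aromatic carbon gives a 17-fold lower number from compound 1 to compound 4 (1.24 log units; beyond the scatter), so replacing the whole group has a large effect here. Changing only a substituent on the ring gave a much smaller shift, a 2.4-fold higher number from compound 1 to compound 2 (0.38 log units; beyond the scatter), which the earlier compounds alone could not have shown to understate how much this position can matter. The group that leaves has 7 heavy atoms and a double bond outside aromatic rings, while pyrrolidin-1-yl has 5 heavy atoms and no such bond, so a group without that carbonyl and methyl is tolerated at this position and gives the lowest number of the series. Nothing available bears on what lies behind this large step.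

Because the carbonyl and the methyl go together in this one change, the compounds shown leave open how much of the step belongs to each, and pyrrolidin-1-yl carrying a methyl on a saturated ring carbon would begin to separate the two. They also leave open whether the gain is particular to this five-membered ring or extends to a piperidin-1-yl ring or an open-chain dimethylamino group on the same aromatic carbon.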